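The source may report more compounds than this note shows. Statements on the series, on what has been measured and on what is new or still open speak of the compounds shown alone.

Compound 1, with the structure `OC[C@H]1O[C@@H](n2cnc3c(NCc4ccc(Br)cc4)ncnc32)[C@H](O)[C@@H]1O`, is the starting point. In a functional assay on HOS cells (Homo sapiens) for antiproliferative activity, with a stated time of 72 h (on this read-out lower numbers stand for stronger inhibition and higher numbers for weaker inhibition), compound 1 gives > 166000 nM, which is a limit of the assay rather than a number. Compound 2 `OC[C@H]1O[C@@H](n2cnc3c(NCc4ccc(Cl)c(Cl)c4)ncnc32)[C@H](O)[C@@H]1O` gives > 166000 nM, again only a limit. Compound 3 `OC[C@H]1O[C@@H](n2cnc3c(NCc4ccc(F)cc4Cl)ncnc32)[C@H](O)[C@@H]1O` gives > 166000 nM, likewise a limit. The steps a step that the two limits leave unreadable from compound 1 to compound 2 and a step that the two limits leave unreadable from compound 1 to compound 3 therefore cannot be sized, because of the limit of > 166000 nM in this assay, at which 3 of the 3 values shown sit.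

Compound 4, with the structure `Cc1ccc(O)c(CNc2ncnc3c2ncn3[C@@H]2O[C@H](CO)[C@@H](O)[C@H]2O)c1`, is not yet measured. It differs from compound 1 as follows: 2-hydroxy-5-methylphenyl in place of 4-bromophenyl on a saturated chain carbon bound to a nitrogen on an aromatic ring. Of the measured steps, those from compound 1 to compound 2 and from compound 1 to compound 3 also swap the group on this same saturated chain carbon, and none of them reveals any shift, since every value sits at the limit. No readable step bears on the change to compound 4, so there is no basis to expect a move beyond the scatter in this assay. Compound 4 is expected to give about 166000 nM, with a range from 40000 nM to 700000 nM. That estimate means an expected step of a number no higher from compound 1 to compound 4 (the limit leaves the size open), most likely again reported only as a limit.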

Compound 4, half-maximal inhibitory concentration: > 166000 nM
Compound 4: only a limit was reported; the forecaster's own chance of this, stated with the estimate: 70%; the middle value lies on the limit itself.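

Compound 4 also gives only a limit, so no step between it and compound 1, compound 2 or compound 3 can be read: the limit of > 166000 nM in this assay, at which 4 of the 4 values shown sit.

The compounds shown leave open how far these four differ in this assay, and whether any group at this place on the shared core would give a measurable value.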